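This account rests on a few compounds, and the source may have more. Where it says the series, first, only, none or still open, it means among the compounds named here.

Measured so far:
Compound 1, `Cc1cc(C)c2c(c1)CN(c1ccc3c(=O)cc(-c4ccccc4)oc3c1)CO2`, gives 48.4% in a functional assay on MCF7 cells (Homo sapiens) for inhibition, read by MTT assay, with a stated time of 48 h, tested at 60 ug/mL; a higher number here means more inhibition of growth at the concentration tested, a lower number less inhibition of growth.
Compound 2, `COc1cc2c(c(OC)c1)OCN(c1ccc3oc(-c4ccccc4)cc(=O)c3c1)C2`, gives 99.1% in this assay.

Compound 1 holds the lower of the two numbers; compound 2 sits higher by a gap beyond the usual scatter. Among the measured compounds shown here, no step between compounds differing in one place has been established, and compound 2 differs from compound 1 in more than one place, so the two values show only that compound 1 inhibits growth less than compound 2 at the concentration tested.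

The next compound is compound 3, `Cc1cccc2c1OCN(c1ccc3c(=O)cc(-c4ccccc4)oc3c1)C2`. Relative to compound 1 the change is hydrogen in place of methyl on an aromatic carbon. The methyl that leaves sits meta to a methyl group and para to a fused ring; the remainder of the shared core of compound 1 is unchanged. For the measured compounds named here, no measured pair shows what removing a methyl does on this core, so the direction of the step is open. The step is expected to be small, within or close to the scatter, and a number 4.4 percentage points lower from compound 1 to compound 3 (within the scatter) is the estimated change in this assay. Compound 3 is expected to give 44%, within 22% to 68%.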

Compound 3, percent growth inhibition at one concentration: 66.6%
Beside the measured number, compound 3's estimate is 22.6 percentage points below it, within the range that was stated.
By their numbers in this assay, from the lowest: compound 1; then compound 3; then compound 2.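

Hydrogen in place of methyl on an aromatic carbon, meta to a methyl group and para to a fused ring, is the first single change that can be read on this core: in this assay it gives a number 18.2 percentage points higher from compound 1 to compound 3 (beyond the scatter) and so moves growth inhibition upward rather than leaving it flat. The methyl that leaves is therefore not required for growth inhibition at the concentration tested, and compound 1 is the less inhibitory member of this pair, with the other methyl present in both compounds. No measurement at hand accounts for the rise, which stands as an observed difference only.

Going by these compounds, whether the gain comes from hydrogen specifically at this aromatic carbon remains open, as a chlorine, an amine or a carboxylic acid there would show whether other groups also give more inhibition than methyl does. Also open, on these data alone, is what replacing the methyl that remains in compound 3 would do, for instance with hydrogen or with a longer chain such as ethyl.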